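Swapping a bromophenyl for a pyridinyl on a shared core

This account rests on a few compounds, and the source may have more. Where it says the series, first, only, none or still open, it means among the compounds named here.

Among the measured compounds shown here, compound 1 `COC(=O)c1sc2cc(Nc3ccccc3Br)cnc2c1N` gives 34100 nM in a functional assay on A375-C5 cells (Homo sapiens) for inhibition, read by sulforhodamine B assay, with a stated time of 48 h (on this read-out lower numbers stand for stronger inhibition of growth and higher numbers for weaker inhibition of growth), one of only two numbers known here, and compound 2 `COC(=O)c1sc2cc(Nc3ccc(F)cc3Br)cnc2c1N` gives 34000 nM in this assay, within the scatter of it. For the measured compounds named here, the single recorded step, a 1.0-fold lower number from compound 1 to compound 2 (0.00 log units; within the scatter), concerns fluoro in place of hydrogen on an aromatic carbon and does not touch the exchange at hand. Compound 3 `COC(=O)c1sc2cc(Nc3cccnc3)cnc2c1N` differs from compound 1 by pyridin-3-yl in place of 2-bromophenyl on a nitrogen on an aromatic ring. Going by the values given here, no measured step covers such a replacement, so the expectation rests on the two close numbers alone. The step of a 1.2-fold higher number from compound 1 to compound 3 (0.07 log units; within the scatter) is expected to be small. Compound 3 is thus estimated at 40000 nM in this assay, within a wide range from 12000 nM to 130000 nM.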

Compound 3, concentration for 50% growth inhibition: > 150000 nM
Compound 3: only a limit was reported; the forecaster's own chance of this, stated with the estimate: 15%; at least 3.7-fold (0.57 log units) between middle value and limit.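

Unlike the fluoro exchange, which stayed within the scatter, pyridin-3-yl in place of 2-bromophenyl on this nitrogen moves the read-out, with an at least 4.3-fold higher number from compound 1 to compound 3 (0.64 log units; beyond the scatter) in this assay. This position is therefore not indifferent to the group it carries, and growth inhibition is weaker with pyridin-3-yl. For compound 3 only a limit of the assay stands, not a number: the limit of > 150000 nM in this assay, at which 1 of the 3 values shown sits.

The compounds shown do not separate the loss of the bromine from the entry of the ring nitrogen. On these data alone, how a plain phenyl or a pyridin-4-yl would read here remains open.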